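The source may report more compounds than this note shows. Statements on the series, on what has been measured and on what is new or still open speak of the compounds shown alone.

Among the compounds with values here, in a functional assay on HepG2 cells (Homo sapiens) for antiproliferative activity, read by MTT assay, with a stated time of 24 h (a higher number here means a weaker inhibitor, a lower number a stronger inhibitor), compound 2 `O=c1[nH]cc(S(=O)(=O)Nc2cccc(-c3cn(-c4ccccc4)nn3)c2)c(=O)[nH]1` gives 11200 nM, the only actual number so far. Compound 1 `O=c1[nH]cc(S(=O)(=O)Nc2ccccc2-c2cn(-c3ccc(F)cc3)nn2)c(=O)[nH]1` reaches only a limit, > 20000 nM, and not a number. Compound 3 `O=c1[nH]cc(S(=O)(=O)Nc2cccc(-c3cn(-c4ccccc4Cl)nn3)c2)c(=O)[nH]1` differs from compound 2 in one place: phenyl becomes 2-chlorophenyl, with chloro in place of hydrogen on an aromatic carbon. Within the data shown here, no measured pair shows what such a change does, so only a small shift towards a stronger inhibitor is expected, no larger than the usual scatter: the estimated change is a 1.2-fold lower number from compound 2 to compound 3 (0.09 log units; within the scatter). For compound 3 the expected value is 9000 nM, with an estimated range from 3500 nM to 20000 nM.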

Compound 3, half-maximal inhibitory concentration: 4030 nM
For compound 3 the middle estimate is 2.2-fold (0.35 log units) above the measured one; measured number inside the range.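

In this assay chloro in place of hydrogen on an aromatic carbon, ortho to a large group, gives a 2.8-fold lower number from compound 2 to compound 3 (0.44 log units; beyond the scatter) and this modest step lies beyond the scatter. It is the first measured step among these compounds, and it shows that this position on the ring can respond to a single added atom, with a stronger inhibitor as the outcome. Nothing measured here accounts for the step. As far as these compounds go, whether a methoxy group or an amine at the same position would give a similar step remains open.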